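Adding a cyano group to compound 2

This account rests on a few compounds, and the source may have more. Where it says the series, first, only, none or still open, it means among the compounds named here.

Measured so far:
Compound 1 `CC(=O)N[C@@H]1CCC[C@H](C(=O)Nc2cc(-c3cnn4c3CCC4)c(Cl)cn2)C1` value 2.9
Compound 2 `CC(=O)N[C@@H]1CCC[C@H](C(=O)Nc2cc(-c3cnn4c3CC(C)(C)C4)ccn2)C1` value 2.8

In a physicochemical assay for lipophilicity, using the shake flask method, measured as octanol-water partition, at pH 7.4 (a higher number here means a more lipophilic compound, a lower number a more polar compound), compound 2 stands at 2.8 and compound 1 stands at 2.9 on the same scale. These two numbers lie within the usual scatter of repeated measurements, so neither compound can be ranked above the other.

Among the measured compounds shown here, the next compound is compound 3 `CC(=O)N[C@@H]1CCC[C@H](C(=O)Nc2cc(-c3cnn4c3CC(C)(C)C4)c(C#N)cn2)C1` and it has cyano in place of hydrogen on an aromatic carbon as its only difference from compound 2. That carbon belongs to a six-membered aromatic ring with 1 nitrogen. For the measured compounds named here, no measured pair of compounds shows this change, and compound 1 and compound 2 differ in more than one place, so their values offer no direct guide. A small fall in this assay is expected, of a size that may not clear the scatter. The expected change is a number 0.20 log units lower from compound 2 to compound 3 (within the scatter) on this scale. The estimate for compound 3 is 2.6 with an expected range from 2.2 to 3 for the measurement.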

Compound 3, distribution coefficient: 3.2
Beside the measured number, compound 3's estimate is 0.60 log units below it; measured number above the stated range.
By their numbers in this assay, from the lowest: compounds 2, 1 and 3 (each within the scatter of the next, the first and the last beyond it).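

In this assay, among the compounds shown here, putting cyano in place of hydrogen on this aromatic carbon gives a number 0.40 log units higher from compound 2 to compound 3 (beyond the scatter) and this is the first reading of a single change in the set, as compound 1 and compound 2 differ in more than one place. It shows that at this carbon, two atoms from the ring nitrogen and flanked by large groups ortho and para to it, a group bringing 2 heavy atoms and 1 hydrogen-bond acceptor can go with a rise in the number, clear of the scatter, rather than a fall or no change at all. The data shown offer no measurement that explains the direction of this step, so it stands as an observation from one pair of compounds.

Going by these compounds, whether the same swap gives a step of similar size and direction on the core of compound 1 remains open, since one pair cannot establish a general rule. Also open, on these data alone, is how the number would respond at this same carbon to other groups, such as a methoxy group, an amine or a carboxylic acid.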